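Chloro on the pyridin-3-yl arm of compound 3

The compounds below may be only part of what the source reports. "The series", "measured", "known", "first", "only" and "open" are said of these compounds alone.

Measured in a functional assay on HepG2 cells (Homo sapiens) for antiproliferative activity, read by MTT assay, with a stated time of 48 h; a higher number here means a weaker inhibitor, a lower number a stronger inhibitor:
compound 1, `Clc1cccc(Nc2ncnc3ccc(NCc4ncc5ccccc5n4)cc23)c1`: 5650 nM
compound 2, `Cc1cccc(CNc2ccc3ncnc(Nc4cccc(Cl)c4)c3c2)n1`: 3630 nM
compound 3, `O=C(/C=C/c1cccnc1)Nc1ccc2ncnc(Nc3cccc(Cl)c3)c2c1`: 9120 nM

Compound 3 gives the highest number of the three in this assay; its gap to compound 1 is within the scatter, its gap to compound 2 is beyond it. Going by the values given here, the only step between two measured compounds that differ in one place is a 1.6-fold lower number from compound 1 to compound 2 (0.19 log units; within the scatter), and that step changes the group on the saturated chain carbon bound to the ring nitrogen, not the amide-linked arm carried by compound 3.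

Compound 4 is `O=C(/C=C/c1cccnc1Cl)Nc1ccc2ncnc(Nc3cccc(Cl)c3)c2c1`. It differs from compound 3 by chloro in place of hydrogen on an aromatic carbon. Among the compounds with values here, no measured pair shows the effect of a chloro substituent on this six-membered aromatic ring with one nitrogen, so nothing speaks for a change beyond the scatter in either direction. The step from compound 3 to compound 4 in this assay is therefore expected to be small, a 1.3-fold lower number from compound 3 to compound 4 (0.11 log units; within the scatter). For compound 4 the estimate in this assay is 7000 nM, with a range from 2500 nM to 20000 nM.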

Compound 4, half-maximal inhibitory concentration: 4420 nM
Estimate against measurement, compound 4: 1.6-fold (0.20 log units) above; the measured number falls inside the stated range.
By their numbers in this assay, from the lowest: compounds 2, 4, 1 and 3 (each within the scatter of the next, the first and the last beyond it).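

In this assay, the change from pyridin-3-yl to 2-chloropyridin-3-yl gives a 2.1-fold lower number from compound 3 to compound 4 (0.31 log units; beyond the scatter) as a modest step. It is the only step shown on the amide-linked arm, and it shows that chloro on this aromatic carbon, next to the ring nitrogen and ortho to a large group, lowers the number beyond the scatter rather than raising it. Nothing measured here accounts for the step.

As far as these compounds go, whether this step is specific to chloro remains open, as fluoro, methyl, methoxy or an amine on the same carbon would test that. From the compounds shown here alone, it is also open whether chloro on another carbon of the same ring gives a step of similar size, and whether the step carries over to the arms of compound 1 and compound 2.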